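Aryl-aminopyrimidine ureas: NCI-H1581 inhibition at one concentration

The compounds below may be only part of what the source reports. "The series", "measured", "known", "first", "only" and "open" are said of these compounds alone.

Measured so far:
compound 1 `COc1cc(NC(=O)Nc2cc(Nc3cccc(C(C)(C)C)c3)ncn2)cc(OC)c1` — 35.1%
compound 2 `CC(C)(C)c1cccc(Nc2cc(NC(=O)Nc3c(Cl)cccc3Cl)ncn2)c1` — 64.3%

Within the data shown here, compound 1 sits lowest of the two numbers in a functional assay on NCI-H1581 cells (Homo sapiens) for inhibition, read by MTT assay, with a stated time of 48 h, tested at 10 uM; on this read-out higher numbers stand for more inhibition at the one concentration tested (going by the name of the read-out) and lower numbers for less inhibition; the only neighbour is compound 2, reached by a number 29.2 percentage points higher from compound 1 to compound 2 (beyond the scatter) through a change on an amide-type nitrogen.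

Compound 3 `COc1cc(NC(=O)Nc2cc(Nc3cc(F)ccc3OC)ncn2)cc(OC)c1` is not yet measured. It differs from compound 1 in 5-fluoro-2-methoxyphenyl in place of 3-(tert-butyl)phenyl on a nitrogen on an aromatic ring. Among the measured compounds shown here, this change sits on a nitrogen on an aromatic ring, a different place from the one altered in the step from compound 1 to compound 2, so that step does not bear on it. For the measured compounds named here, no measured pair varies the group on this nitrogen; the two values shown tell nothing about what a change here does.

Going by the values given here, with no relevant step, the expectation for compound 3 rests on compound 1 alone. The estimated step of a number 3.1 percentage points lower from compound 1 to compound 3 (within the scatter) is therefore set at about none beyond the scatter, with a wide range in both directions. Compound 3 is expected to give 32%, between 8% and 60%.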

Compound 3, a percentage reported as inhibition, at one concentration (the size of the read-out at that concentration, not a potency): 42.1%
For compound 3 the middle estimate is 10.1 percentage points below the measured one; measured number inside the range.
By their numbers in this assay, from the lowest: compounds 1 and 3 (each within the scatter of the next); then compound 2.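

In this assay, among these compounds, the first change on the nitrogen on an aromatic ring, 5-fluoro-2-methoxyphenyl in place of 3-(tert-butyl)phenyl, gives a number 7 percentage points higher from compound 1 to compound 3 (within the scatter) and so does not separate the two groups at this position. Among the compounds shown here, with 3,5-dimethoxyphenyl held on the amide-type nitrogen, this exchange of a carbon-only substituted phenyl for one carrying a hydrogen-bond acceptor leaves the read-out unresolved, and the change on the amide-type nitrogen remains the only step beyond the scatter. Nothing measured here accounts for this result.

Going by these compounds, it remains open whether the two groups on this nitrogen would also stay unresolved in a compound carrying 2,6-dichlorophenyl on the amide-type nitrogen, and whether the single concentration hides a difference in potency between them. Also open, on these data alone, is what a group of another kind would do on this nitrogen, such as a morpholine, a carboxylic acid or a longer alkyl chain in place of the substituted phenyl.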